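Adding a second nitro group to compound 2

The source may report more compounds than this note shows. Statements on the series, on what has been measured and on what is new or still open speak of the compounds shown alone.

Among the compounds with values here, in a functional assay on NMC-797 cells (Homo sapiens) for antiproliferative activity, with a stated time of 48 h (on this read-out lower numbers stand for stronger inhibition and higher numbers for weaker inhibition), compound 2 `O=C1C=C[C@]2(C[C@@H](c3cccc([N+](=O)[O-])c3)O[C@@H](c3ccccc3)O2)O1` gives 160 nM, the lowest of the three numbers measured so far. Compound 4 `O=C1C=C[C@]2(C[C@@H](c3cccc([N+](=O)[O-])c3)O[C@@H](c3cccc([N+](=O)[O-])c3)O2)O1` is still unmeasured and differs from compound 2 by nitro in place of hydrogen on an aromatic carbon. The closest guide is compound 3 `O=C1C=C[C@]2(C[C@@H](c3ccccc3)O[C@@H](c3ccccc3)O2)O1`, which gives 900 nM: a 5.6-fold higher number from compound 2 to compound 3 (0.75 log units; beyond the scatter), a step that takes a nitro group away. Adding one elsewhere may therefore lower the number in this assay, though this is uncertain. Compound 1 `CC1[C@@H](c2cccc([N+](=O)[O-])c2)O[C@@H](c2cccc([N+](=O)[O-])c2)O[C@@]12C=CC(=O)O2` also carries two nitro groups and gives 12000 nM, but its core differs too. A modest step is expected, a 2.3-fold lower number from compound 2 to compound 4 (0.36 log units; beyond the scatter). For compound 4 the estimated value is 70 nM, with an expected range of 20 nM to 400 nM.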

Compound 4, half-maximal inhibitory concentration: 47 nM
Compound 4: the middle estimate sits 1.5-fold (0.17 log units) above what was measured, and the stated range covers the measured number.
By their numbers in this assay, from the lowest: compound 4; then compound 2; then compound 3; then compound 1.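

In this assay the phenyl ring that was bare in compound 2 also accepts a nitro group, and the number falls further (a 3.4-fold lower number from compound 2 to compound 4 (0.53 log units; beyond the scatter)), so nitro groups on both rings go with the lowest number here. Two nitro groups therefore do not account for the high number of compound 1; what separates it from compound 4 is a methyl on a saturated ring carbon (a 260-fold lower number from compound 1 to compound 4 (2.41 log units; beyond the scatter)). Nothing available explains either change. From the compounds shown here alone, whether an amine or a carboxylic acid in place of this nitro group would serve equally well remains open.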